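This account rests on a few compounds, and the source may have more. Where it says the series, first, only, none or still open, it means among the compounds named here.

Of the compounds shown here, two sharing one core have been measured in an assay for binding affinity to 17-beta-hydroxysteroid dehydrogenase type 1 (Homo sapiens), with a stated time of 20 min, tested at 1 uM; on this read-out higher numbers stand for more inhibition at the one concentration tested (going by the name of the read-out) and lower numbers for less inhibition. Compound 1, `Oc1cccc2cc(-c3ccccc3)ccc12`, marks the floor of that read-out: in this assay compound 1 gives < 10%, which is a limit of the assay and not a number, so that one of the two values shown sits at the limit of < 10% in this assay, at which 1 of the 2 values shown sits. Compound 2, `CC(=O)c1ccc(-c2ccc3c(O)cccc3c2)cc1`, carries acetyl in place of hydrogen on an aromatic carbon, and in this assay compound 2 gives 16%. The step between the two is a number at least 6 percentage points higher from compound 1 to compound 2 (that floor lies within the scatter). Compound 2 thus holds the only plain number shown, the other value being a limit.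

Compound 3, `CNS(=O)(=O)c1ccc(-c2ccc3c(O)cccc3c2)cc1`, differs from compound 2 by methylsulfamoyl in place of acetyl on an aromatic carbon. No measured step exchanges one group for another on this aromatic carbon; the only step shown, from hydrogen to acetyl, was small and its floor lay within the scatter. Nothing in hand therefore bears directly on this exchange, and the expectation is a change of no size beyond the scatter. The step from compound 2 to compound 3 is expected to be a number 1 percentage points lower from compound 2 to compound 3 (within the scatter). Compound 3 is estimated to give 15%, with a range from 0% to 40%, and a fair chance that the assay returns only a limit.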

Compound 3, a percentage reported as inhibition, at one concentration (the size of the read-out at that concentration, not a potency): 12%
Beside the measured number, compound 3's estimate is 3 percentage points above it, within the range that was stated.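

In this assay, among the compounds shown here, the exchange of acetyl for methylsulfamoyl on this aromatic carbon, para to a large group, gives a number 4 percentage points lower from compound 2 to compound 3 (within the scatter) and so offers the first direct reading of one group against another at this place. The entering group brings a sulfur atom and a hydrogen-bond donor that acetyl lacks, yet the two groups are not told apart on this read-out. Measured against hydrogen at the same place, methylsulfamoyl gives a number at least 2 percentage points higher from compound 1 to compound 3 (that floor lies within the scatter) and acetyl gives a number at least 6 percentage points higher from compound 1 to compound 2 (that floor lies within the scatter) and neither floor clears the scatter, while the value of compound 1 is a limit of the assay and not a number: the limit of < 10% in this assay, at which 1 of the 3 values shown sits.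

Going by these compounds, what a carboxylic acid, an amine or a longer chain on this aromatic carbon would give remains open, as does whether any group placed here can move the inhibition beyond the scatter. Also open is whether the exchange of acetyl for methylsulfamoyl would read the same on a different core, as every compound shown keeps the shared core.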